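A few compounds are considered here, and "the series" means these few. Any claim that something is new, unique, unknown or untested is made for them only; others in the source may bear on it.

Measured so far in this series:
compound 1 `N[C@@H](COP(=O)(O)OCCCOC(=O)CCc1ccccc1OCCCCOc1ccccc1)C(=O)O` — 6.1%
compound 2 `N[C@@H](COP(=O)(O)OCCCOC(=O)CCc1ccccc1OCc1cccc(Cc2ccccc2)c1)C(=O)O` — 14.5%

Both numbers come from an assay on cells for agonist activity at probable G-protein coupled receptor 34 (Mus musculus), with a stated time of 1 h; a lower number here means a smaller maximal response, a higher number a larger maximal response. Compound 2 holds the higher of the two values, but its nearest neighbour, compound 1, lies within the usual scatter of it, so the two cannot be ordered with any confidence; both sit low on the scale of maximal response.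

Compound 3 `N[C@@H](COP(=O)(O)OCCCOC(=O)CCc1ccccc1OCc1cccc(Oc2ccc(Cl)c(Cl)c2)c1)C(=O)O` is the next member. It differs from compound 2 in one place: 3,4-dichlorophenoxy in place of benzyl on an aromatic carbon. Among the measured compounds shown here, no step between two measured compounds is available, so there is no measured precedent for this kind of change in this assay. The expectation is therefore a step from compound 2 to compound 3 of small size, a number 0.5 percentage points higher from compound 2 to compound 3 (within the scatter), not clearly beyond the scatter, with the direction left open. On that basis compound 3 is estimated to give 15% in this assay, expected to fall between 4% and 32%.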

Compound 3, largest response reached (Emax), in percent of the reference or control that the assay uses: 18%
The estimate for compound 3 lay 3 percentage points below the measured number; the range from low to high includes it.
By their numbers in this assay, from the lowest: compounds 1, 2 and 3 (each within the scatter of the next, the first and the last beyond it).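

In this assay, 3,4-dichlorophenoxy in place of benzyl on an aromatic carbon, meta to a large group, comes with a number 3.5 percentage points higher from compound 2 to compound 3 (within the scatter). Among the compounds shown here, this is the first step that can be read at this position, and the response to the exchange cannot be told apart from that of compound 2, even though the entering group brings 9 heavy atoms in place of 7, two of them chlorine, and 1 hydrogen-bond acceptor in place of 0. No measurement at hand offers an explanation for this step.

Unsubstituted phenoxy at this place would show whether the ether oxygen or the two chlorines carry any part of the step. Going by these compounds, whether an amine or a carboxylic acid on the same aromatic carbon would move the response beyond the scatter remains open.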